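Bromo for fluoro: compound 4 in the series

A few compounds are considered here, and "the series" means these few. Any claim that something is new, unique, unknown or untested is made for them only; others in the source may bear on it.

Compound 3 `COc1cc2c(Oc3ccc(NC(=O)c4nn(-c5ccccc5F)c(=O)c5ccccc45)cc3F)ccnc2cc1OCCCN1CCC(C)CC1` gives 510 nM in a functional assay on HT-29 cells (Homo sapiens) for cytotoxicity, read by MTT assay, with a stated time of 72 h (on this read-out lower numbers stand for stronger inhibition and higher numbers for weaker inhibition), the second highest of three numbers. Compound 2 `COc1cc2c(Oc3ccc(NC(=O)c4nn(-c5cccc(F)c5)c(=O)c5ccccc45)cc3F)ccnc2cc1OCCCN1CCC(C)CC1` gives 500 nM. The step of a 1.0-fold higher number from compound 2 to compound 3 (0.01 log units; within the scatter) lies within the scatter. Compound 1 `COc1cc2c(Oc3ccc(NC(=O)c4nn(-c5ccccc5)c(=O)c5ccccc45)cc3F)ccnc2cc1OCCCN1CCC(C)CC1` gives 1040 nM, the highest number; the steps of a 2.1-fold lower number from compound 1 to compound 2 (0.32 log units; beyond the scatter) and a 2.0-fold lower number from compound 1 to compound 3 (0.31 log units; beyond the scatter) were both modest and beyond the scatter. Compound 4 `COc1cc2c(Oc3ccc(NC(=O)c4nn(-c5ccccc5Br)c(=O)c5ccccc45)cc3F)ccnc2cc1OCCCN1CCC(C)CC1` carries the change (bromo in place of fluoro on an aromatic carbon). Within the data shown here, no measured step exchanges one halogen for another; the halogen steps on hand show only that introducing fluoro at either place lowered the number by a similar, modest amount. On that basis the expected step of a 1.0-fold lower number from compound 3 to compound 4 (0.01 log units; within the scatter) is none beyond the scatter. Compound 4 is estimated at 500 nM, with a range from 200 nM to 1300 nM.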

Compound 4, half-maximal inhibitory concentration: 950 nM
Compound 4: the middle estimate sits 1.9-fold (0.28 log units) below what was measured; the measured number falls inside the stated range.
By their numbers in this assay, from the lowest: compounds 2, 3, 4 and 1 (each within the scatter of the next, the first and the last beyond it).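

In this assay bromo at this place is not resolved from fluoro: a 1.9-fold higher number from compound 3 to compound 4 (0.27 log units; within the scatter) and a 1.9-fold higher number from compound 2 to compound 4 (0.28 log units; within the scatter) both stay inside the scatter. Nor is it resolved from hydrogen, with a 1.1-fold lower number from compound 1 to compound 4 (0.04 log units; within the scatter) also inside it, whereas a 2.0-fold lower number from compound 1 to compound 3 (0.31 log units; beyond the scatter) for fluoro at the same place stands beyond it. No other measurement on hand bears on these numbers.

On these data alone, whether chloro, methoxy or an amine at this place would separate from hydrogen stays open. So does whether bromo behaves alike at the place held by the fluoro of compound 2.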